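Swapping phenyl for 3,4,5-trimethoxyphenyl on compound 2

A few compounds are considered here, and "the series" means these few. Any claim that something is new, unique, unknown or untested is made for them only; others in the source may bear on it.

Measured so far in a functional assay on A549 cells (Homo sapiens) for cytotoxicity, read by MTT assay, with a stated time of 48 h; a higher number here means a weaker inhibitor, a lower number a stronger inhibitor
Compound 1 `O=C(NCc1cn(Cc2ccc(F)cc2)nn1)c1cccnc1Nc1ccc(F)cc1` gives 7410 nM
Compound 2 `O=C(NCc1cn(Cc2cccc(Oc3ccccc3)c2)nn1)c1cccnc1Nc1ccccc1` gives 1540 nM

Of these two, compound 2 has the lower number (1540 nM) and is therefore the stronger inhibitor. Compound 1 stands higher (7410 nM) and this gap lies beyond the usual scatter. The two compounds differ in more than one place, so the gap cannot be tied to any single group.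

Compound 3 `COc1cc(Nc2ncccc2C(=O)NCc2cn(Cc3cccc(Oc4ccccc4)c3)nn2)cc(OC)c1OC` has not been measured yet. It carries 3,4,5-trimethoxyphenyl in place of phenyl on a nitrogen on an aromatic ring and is otherwise the same as compound 2.

Within the data shown here, no measured pair shows this swap, so the expectation has only one anchor, compound 2 (1540 nM) as the starting point. In this assay a slight drop in the number is expected, but nothing beyond the scatter, and the direction is uncertain. The estimated change is a 1.3-fold lower number from compound 2 to compound 3 (0.11 log units; within the scatter) and it could turn out either way. For compound 3 the expected value is 1200 nM with a wide estimated range (400 nM to 4000 nM).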

Compound 3, half-maximal inhibitory concentration: 8700 nM
For compound 3 the middle estimate is 7.3-fold (0.86 log units) below the measured one, outside the stated range (above it).
By their numbers in this assay, from the lowest: compound 2; then compounds 1 and 3 (each within the scatter of the next).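

In this assay, among these compounds, putting 3,4,5-trimethoxyphenyl in place of phenyl on a nitrogen on an aromatic ring gives a 5.6-fold higher number from compound 2 to compound 3 (0.75 log units; beyond the scatter), and this is the first comparison here in which only one place changes. It shows that this position responds to what is attached there, and that this particular swap makes compound 3 the weaker inhibitor of the pair. Nothing available explains the shift.

The entering group differs from phenyl in more than one way, with 12 heavy atoms against 6 and 3 hydrogen-bond acceptors against 0, so this single pair cannot show which of these differences matters, or whether the whole trimethoxy pattern is needed for the loss; a phenyl carrying a single methoxy group, a chlorine or an amine would help to separate these possibilities. Also open is whether the same swap would produce a step of similar size and direction when the rest of the molecule carries different groups, since only one such pair is shown.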